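Swapping the Sulfonyl Aryl Group on a Benzoxazole Core

The source may hold more compounds than are shown below. What is called first, only, known or untested is meant among the compounds shown, and "the series" means these compounds.

Of the compounds shown here, three have been tested in an assay for inhibition of HSP60/HSP10 (Homo sapiens), with a stated time of 60 min; a lower number here means a stronger inhibitor, a higher number a weaker inhibitor. Compound 1 `O=S(=O)(Nc1ccc(-c2nc3cc(NS(=O)(=O)c4ccc(Cl)s4)ccc3o2)cc1)c1cccc(C(F)(F)F)c1` gives 4500 nM in this assay. Compound 2 `O=[N+]([O-])c1cc(S(=O)(=O)Nc2ccc3oc(-c4ccc(NS(=O)(=O)c5ccc(Cl)s5)cc4)nc3c2)ccc1Cl` gives 1000 nM. Compound 3 `O=[N+]([O-])c1cc(S(=O)(=O)Nc2ccc(-c3nc4cc(NS(=O)(=O)c5ccc(Cl)s5)ccc4o3)cc2)ccc1Cl` gives 2100 nM. Compound 2 has the lowest number of the three, and its gaps to compound 3 and to compound 1 are both beyond the usual scatter, so among these three it is the strongest inhibitor.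

Compounds 1 and 3 share a core and differ in one place: 3-(trifluoromethyl)phenyl in place of 4-chloro-3-nitrophenyl on a sulfonyl sulfur. That change made the step of a 2.1-fold higher number from compound 3 to compound 1 (0.33 log units; beyond the scatter), a loss of inhibition that is modest but beyond the scatter.

Compound 4 `O=S(=O)(Nc1ccc2oc(-c3ccc(NS(=O)(=O)c4ccc(Cl)s4)cc3)nc2c1)c1cccc(C(F)(F)F)c1` has not yet been measured. It is built from compound 2 by the same change: 3-(trifluoromethyl)phenyl in place of 4-chloro-3-nitrophenyl on a sulfonyl sulfur. Compounds 2 and 3 are made of the same atoms joined differently, and the difference between the two cores is not broken down here. The two "place" descriptions agree word for word, so this is the same change made on a different core.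

Because compound 3 moved to compound 1 by a 2.1-fold higher number from compound 3 to compound 1 (0.33 log units; beyond the scatter), compound 4 is expected to sit at a higher number than compound 2 by a step of about a 2.1-fold higher number from compound 2 to compound 4 (0.32 log units; beyond the scatter). On these data alone, whether a different core carries the change identically is unknown, so the range is kept wide. Compound 4 is estimated to give 2100 nM in this assay, likely between 900 nM and 5000 nM.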

Compound 4, half-maximal inhibitory concentration: 5000 nM
For compound 4 the middle estimate is 2.4-fold (0.38 log units) below the measured one, and the stated range covers the measured number.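

The new measurement gives a second case of 3-(trifluoromethyl)phenyl in place of 4-chloro-3-nitrophenyl on a sulfonyl sulfur: in this assay the swap produced a 5.0-fold higher number from compound 2 to compound 4 (0.70 log units; beyond the scatter) and so again a loss of inhibition. Set side by side, the two steps point the same way and their sizes cannot be told apart: the same change on two cores in this assay, a 2.1-fold higher number (0.33 log units; beyond the scatter) from compound 3 to compound 1 and a 5.0-fold higher number (0.70 log units; beyond the scatter) from compound 2 to compound 4, 2.3-fold (0.37 log units) apart, within the scatter of two such steps. So on these two cores the change carried over in direction, and the larger-looking second step should not be read as a real difference in size, but two pairs say nothing about other cores and do not explain why inhibition falls.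

The compounds shown leave open how other groups on that sulfonyl sulfur would behave, for instance a plain phenyl, or a phenyl carrying only the chlorine or only the nitro group, which would separate the two parts of 4-chloro-3-nitrophenyl. Also open, on these data alone, is whether inhibition would survive with no aromatic ring at that place, such as a short alkyl chain or a chain ending in an amine or a carboxylic acid.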